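The source may report more compounds than this note shows. Statements on the series, on what has been measured and on what is new or still open speak of the compounds shown alone.

Compound 1 `CCn1c(C(=O)N(CCC#N)CCC#N)ccc1C(CC)(CC)c1ccc(OCCC(O)(CC)CC)c(C)c1` was tested in an assay on cells for agonist activity at vitamin D3 receptor (Homo sapiens), with a stated time of 96 h; a lower number here means that less compound is needed, a higher number that more compound is needed for the effect. In this assay compound 1 gives > 10000 nM, which is a limit of the assay and not a number. Two further compounds share its core and differ only at the amide. Compound 2 `CCn1c(C(=O)Nc2ccc(OC(F)(F)F)cc2)ccc1C(CC)(CC)c1ccc(OCCC(O)(CC)CC)c(C)c1` gives in this assay > 10000 nM, again a limit rather than a number. Compound 3 `CCC(C)C(NC(=O)c1ccc(C(CC)(CC)c2ccc(OCCC(O)(CC)CC)c(C)c2)n1CC)C(=O)OC` gives in this assay > 10000 nM, also a limit. The steps a step that the two limits leave unreadable from compound 1 to compound 2, a step that the two limits leave unreadable from compound 1 to compound 3 and a step that the two limits leave unreadable from compound 2 to compound 3 can therefore not be sized, because of the limit of > 10000 nM in this assay, at which 3 of the 3 values shown sit.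

Compound 4 `CCn1c(C(=O)NC(CO)CCO)ccc1C(CC)(CC)c1ccc(OCCC(O)(CC)CC)c(C)c1` has not yet been measured. It differs from compound 1 at the carbonyl carbon: a group of 7 heavy atoms (4 carbon, 1 nitrogen, 2 oxygen; no ring) in place of a group of 9 heavy atoms (6 carbon, 3 nitrogen; no ring), on a carbonyl carbon. Among the measured compounds shown here, no measured step covers this exchange, and the three steps that swap groups on the same carbonyl carbon all run between limits, so they give no direction and no size. Compound 4 is therefore expected to give 20000 nM, between 5000 nM and 100000 nM, most likely reported again only as a limit. The expected step is a step that the limit leaves unreadable from compound 1 to compound 4.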

Compound 4, half-maximal effective concentration: 2490 nM
Compound 4: the middle estimate sits 8.0-fold (0.90 log units) above what was measured; the measured number lies below the stated range.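

Among the compounds shown here, compound 4, with 3-hydroxy-1-(hydroxymethyl)propyl on the amide-type nitrogen, shows that the group on this carbonyl carbon can bring the compound within the measurable range of this assay, which none of the earlier compounds did. The change gives an at least 4.0-fold lower number from compound 1 to compound 4 (0.60 log units; beyond the scatter), along with an at least 4.0-fold lower number from compound 3 to compound 4 (0.60 log units; beyond the scatter) and an at least 4.0-fold lower number from compound 2 to compound 4 (0.60 log units; beyond the scatter), and each of these sizes is only a minimum, since one end of each step is a limit. The three steps among compounds 1, 2 and 3 remain unreadable because their values are not numbers: the limit of > 10000 nM in this assay, at which 3 of the 4 values shown sit.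

On these data alone, with a single compound giving a number, it remains open whether both hydroxyl groups of this chain are needed. Also open, as far as these compounds go, is how a simple 2-hydroxyethyl chain, a carboxylic acid or an amine on the same nitrogen would compare.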